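A few compounds are considered here, and "the series" means these few. Any claim that something is new, unique, unknown or untested is made for them only; others in the source may bear on it.

Series notes. Compound 1 `CN(C)C(=O)c1cc2cnc(Nc3ccc(NC(=O)CCCN=C=S)cc3)nc2n1C1CCCC1`, compound 2 `CN(C)C(=O)c1cc2cnc(Nc3ccc(NC(=O)CCCCCN=C=S)cc3)nc2n1C1CCCC1` and compound 3 `CN(C)C(=O)c1cc2cnc(Nc3ccc(NC(=O)CCCCCCN=C=S)cc3)nc2n1C1CCCC1` share one core and differ only in the chain that carries the isothiocyanate. In a functional assay on A549 cells (Homo sapiens) for inhibition, read by CCK-8 assay, with a stated time of 72 h, tested at 1 uM (a higher number here means a stronger effect of the compound at the concentration tested, a lower number a weaker effect), compound 1 gives 56.1%, compound 2 gives 56.1% and compound 3 gives 43.3%. Compound 3 stands lowest of the three: a number 12.8 percentage points lower from compound 1 to compound 3 (beyond the scatter) and a number 12.8 percentage points lower from compound 2 to compound 3 (beyond the scatter), while no change at the digits printed from compound 1 to compound 2 (within the scatter). Compound 4 `CN(C)C(=O)c1cc2cnc(Nc3ccc(N=C=S)cc3)nc2n1C1CCCC1` is the next step: a group of 3 heavy atoms (1 carbon, 1 nitrogen, 1 sulfur; no ring) in place of a group of 12 heavy atoms (8 carbon, 2 nitrogen, 1 oxygen, 1 sulfur; no ring), on an aromatic carbon. Within the data shown here, none of the measured steps covers such a change; they exchange chain segments only, and the longest chain, in compound 3, sits lowest. Lacking a bearing step, the expected value for compound 4 is placed near the shorter-chain compounds, an estimate of 50% with range 30% to 70%, which for compound 4 means an expected a number 6.7 percentage points higher from compound 3 to compound 4 (within the scatter).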

Compound 4, a percentage reported as inhibition, at one concentration (the size of the read-out at that concentration, not a potency): 44.4%
Compound 4: the middle estimate sits 5.6 percentage points above what was measured, within the range that was stated.
By their numbers in this assay, from the lowest: compounds 3 and 4 (each within the scatter of the next); then compounds 1 and 2 (each within the scatter of the next).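

Setting the isothiocyanate directly on the aromatic carbon in place of the whole chain gives in this assay a number 1.1 percentage points higher from compound 3 to compound 4 (within the scatter), so removing the chain and extending it to its longest read alike here. The same change gives a number 11.7 percentage points lower from compound 2 to compound 4 (beyond the scatter) and a number 11.7 percentage points lower from compound 1 to compound 4 (beyond the scatter), so the two shorter chains read beyond the scatter of the chainless form. Nothing measured here accounts for this.

From the compounds shown here alone, whether the isothiocyanate itself carries the effect stays open, and an amine or a carboxylic acid at the chain end would test it. A chain of intermediate length also remains to be read against these values.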